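Phenyl for Butyl on Two Related Acyltransferase Inhibitor Cores

The compounds below may be only part of what the source reports. "The series", "measured", "known", "first", "only" and "open" are said of these compounds alone.

Compound 1, `CCCCCCCCS(=O)(=O)Nc1ccc(-c2ccc(CCCC)cc2)cc1C(=O)O`: 9000 nM
Compound 2, `CCCCCCCCS(=O)(=O)Nc1ccc(-c2ccc(-c3ccccc3)cc2)cc1C(=O)O`: 29100 nM
Compound 3, `CCCCCCCCS(=O)(=O)Nc1ccc(C(=O)c2ccc(CCCC)cc2)cc1C(=O)O`: 31700 nM

All three were tested in an assay on mitochondria (strain BALB/c) for inhibition of glycerol-3-phosphate acyltransferase 1, mitochondrial (Mus musculus), read by scintillation counting, with a stated time of 10 min; on this read-out lower numbers stand for stronger inhibition and higher numbers for weaker inhibition. Compound 1 gives 9000 nM, compound 2 gives 29100 nM, and compound 3 gives 31700 nM. The values of compound 2 and compound 3 lie within the usual scatter of each other, while compound 3 stands beyond the scatter from compound 1.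

From compound 1 to compound 2 the change is phenyl in place of butyl on an aromatic carbon, and it produces a 3.2-fold higher number from compound 1 to compound 2 (0.51 log units; beyond the scatter). The same change, (phenyl in place of butyl on an aromatic carbon), turns compound 3 into the untested compound 4, `CCCCCCCCS(=O)(=O)Nc1ccc(C(=O)c2ccc(-c3ccccc3)cc2)cc1C(=O)O`. It occurs twice among these compounds, and the two cores on which it is made differ in a way that is not broken down here. Since the change sits in the same surroundings both times, compound 4 is expected to show a step like the earlier one, a 2.8-fold higher number from compound 3 to compound 4 (0.45 log units; beyond the scatter), resting on the fact that compound 1 and compound 2 show a 3.2-fold higher number from compound 1 to compound 2 (0.51 log units; beyond the scatter). Compound 4 is therefore estimated at 90000 nM, between 30000 nM and 270000 nM.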

Compound 4, half-maximal inhibitory concentration: 13000 nM
For compound 4 the middle estimate is 6.9-fold (0.84 log units) above the measured one; the whole stated range lies above it.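

Phenyl in place of butyl does not behave the same way on the two cores in this assay. On the second core the change gives a 2.4-fold lower number from compound 3 to compound 4 (0.39 log units; beyond the scatter), which runs in the opposite direction to the step on the first core, so the earlier step cannot be carried across as a fixed increment in this series: the same change on two cores in this assay, a 3.2-fold higher number (0.51 log units; beyond the scatter) from compound 1 to compound 2 and a 2.4-fold lower number (0.39 log units; beyond the scatter) from compound 3 to compound 4, 7.9-fold (0.90 log units) apart, beyond the scatter of two such steps

This rests on a single pair of compounds on each core, and it does not show which difference between the cores goes with the reversal, nor whether it would appear with any other replacement for butyl.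

The compounds shown leave open whether a shorter chain such as ethyl, or a saturated ring such as cyclohexyl, in the place of butyl would also move in opposite directions on the two cores. They also leave open whether an amine carried on the entering phenyl would shift either core's value.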